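This account rests on a few compounds, and the source may have more. Where it says the series, first, only, none or still open, it means among the compounds named here.

Compounds measured in a functional assay on SMMC-7721 cells (Homo sapiens) for cytotoxicity, read by MTT assay, with a stated time of 72 h; on this read-out higher numbers stand for weaker inhibition and lower numbers for stronger inhibition:
compound 1, `[O-][n+]1nc(NCOC2CCCCC2)[n+]([O-])c2ccccc21`, gives 28200 nM
compound 2, `O=[N+]([O-])c1cccc(COCNc2n[n+]([O-])c3ccccc3[n+]2[O-])c1`, gives 8540 nM
compound 3, `COc1ccc2c(c1)[n+]([O-])nc(NCOCc1ccccc1)[n+]2[O-]`, gives 21400 nM

Among these three results compound 1 has the highest number, which on this read-out means the weakest inhibition. Its gap to compound 3 is within the usual scatter, so the two cannot be told apart, while compound 2 sits at a number low enough to lie beyond the scatter, so compound 2 inhibits more strongly than compound 1.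

Compound 4, `[O-][n+]1nc(NCOCc2ccccc2)[n+]([O-])c2ccccc21`, has not yet been measured. It differs from compound 1 in a single place: benzyl in place of cyclohexyl on an oxygen on a saturated carbon. Compound 3 carries the same benzyl group on an oxygen, together with an extra group on its core, and its value is close to that of compound 1. On that basis the step from compound 1 to compound 4 in this assay is expected to be small, toward a slightly lower number if anything, and not clearly beyond the scatter. The estimate for compound 4 is therefore 17000 nM, within a range from 7000 nM to 40000 nM, which corresponds to an expected step of a 1.7-fold lower number from compound 1 to compound 4 (0.22 log units; within the scatter).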

Compound 4, half-maximal inhibitory concentration: 20100 nM
Beside the measured number, compound 4's estimate is 1.2-fold (0.07 log units) below it, within the range that was stated.
By their numbers in this assay, from the lowest: compound 2; then compounds 4, 3 and 1 (each within the scatter of the next).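

In this assay, benzyl in place of cyclohexyl on an oxygen on a saturated carbon gives a 1.4-fold lower number from compound 1 to compound 4 (0.15 log units; within the scatter), so at this place an aromatic ring and a non-aromatic ring of carbon cannot be told apart. Compound 4 also allows two further single changes to be read: hydrogen in place of methoxy on an aromatic carbon gives a 1.1-fold lower number from compound 3 to compound 4 (0.03 log units; within the scatter), while hydrogen in place of nitro on an aromatic carbon gives a 2.4-fold higher number from compound 2 to compound 4 (0.37 log units; beyond the scatter). Within the data shown here, of the three changes, only the one involving nitro separates two compounds, and that gap is modest.

No measurement shown here explains these results. On these data alone, it remains open whether an amine or a carboxylic acid in place of that nitro, or a longer chain in place of benzyl, would move the number in this assay.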